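Swapping an amide for an ester on the linker chain

The source may report more compounds than this note shows. Statements on the series, on what has been measured and on what is new or still open speak of the compounds shown alone.

Compound 1 , with the structure `COCC(=O)NCCCCCC(=O)N[C@H](C(=O)N1C[C@H](O)C[C@H]1C(=O)NCc1ccc(-c2scnc2C)cc1)C(C)(C)C`, is one of two compounds studied in an ADME assay on a cell-free system (plasma, Homo sapiens) for metabolic stability, with a stated time of 90 min; on this read-out higher numbers stand for a more stable compound and lower numbers for a less stable compound. In this assay compound 1 gives 126%, the higher of the two numbers. The second compound, compound 2 with the structure `CCCCOc1ccc(-c2ccc(C(=O)NCCCCCC(=O)N[C@H](C(=O)N3C[C@H](O)C[C@H]3C(=O)NCc3ccc(-c4scnc4C)cc3)C(C)(C)C)cc2)cc1`, gives in this assay 83%, a value that lies below compound 1 by more than the usual scatter. Among the compounds with values here, no pair of measured compounds differs in only one place, so no single change has a measured step attached to it.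

The new compound, compound 3 , has the structure `CCCC(=O)OCCCCCC(=O)N[C@H](C(=O)N1C[C@H](O)C[C@H]1C(=O)NCc1ccc(-c2scnc2C)cc1)C(C)(C)C`. Its difference from compound 1 is (propylcarbonyl)oxy in place of ((methoxymethyl)carbonyl)amino on a saturated chain carbon, five bonds along the chain from a carbonyl carbon. Within the data shown here, since the amide hydrogen of the leaving group is gone and an ester takes its place, and no measured pair shows a change of this kind, the expectation rests on compound 1 alone.

Compound 3 is expected to remain less stable than compound 1, with a step of a number 51 percentage points lower from compound 1 to compound 3 (beyond the scatter) estimated to run beyond the scatter in the downward direction. The estimate for compound 3 in this assay is 75%, with a range from 35% to 110%.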

Compound 3, percent of the compound remaining in the Homo sapiens assay: 13%
Beside the measured number, compound 3's estimate is 62 percentage points above it; measured number outside the range, below it.
By their numbers in the Homo sapiens assay, from the lowest: compound 3; then compound 2; then compound 1.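

At this position the link in the chain matters a great deal: in the Homo sapiens assay, putting (propylcarbonyl)oxy in place of ((methoxymethyl)carbonyl)amino gives a number 113 percentage points lower from compound 1 to compound 3 (beyond the scatter), the first effect in this set that can be tied to one place in the structure. The same change also shows up in a physicochemical assay for lipophilicity, read by LC-MS, using the shake flask method, in phosphate buffer, with a stated time of 50 min, at pH 7.4 (a higher number here means a more lipophilic compound, a lower number a more polar compound), where compound 1 gives 2.2 and compound 3 gives 0.5, so compound 3 is the more polar of the pair. The loss of stability in compound 3 therefore cannot be put down to a rise in lipophilicity, since the two read-outs fall together here: the measured distribution coefficient of compound 1, 2.2, and of compound 3, 0.5, a number 1.70 log units lower (beyond the scatter)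

Going by these compounds, what stays open is which part of the swap carries the loss, since the amide becomes an ester and the methoxymethyl end becomes a propyl end in the same step. A (propylcarbonyl)amino group, which keeps the amide hydrogen, or a ((methoxymethyl)carbonyl)oxy group, which keeps the methoxymethyl end, on the same saturated chain carbon would pull these two parts apart.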